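The source may hold more compounds than are shown below. What is called first, only, known or untested is meant among the compounds shown, and "the series" means these compounds.

Measured compounds:
- compound 1 `CN(c1ccc(Oc2ncnc3ccsc23)cc1)c1nccc(N2CCc3ccccc3C2)n1`, giving 69.9%
- compound 2 `CN(c1ccc(Oc2ncnc3ccsc23)cc1)c1nccc(N2CCCCC2)n1`, giving 65.7%

Both were tested in a functional assay on A549 cells (Homo sapiens) for inhibition, read by MTT assay, with a stated time of 72 h, tested at 20 uM; on this read-out higher numbers stand for more inhibition at the one concentration tested (going by the name of the read-out) and lower numbers for less inhibition. Between them stands one step: a number 4.2 percentage points lower from compound 1 to compound 2 (within the scatter), where piperidin-1-yl takes the place of 1,2,3,4-tetrahydroisoquinolin-2-yl on an aromatic carbon. For the measured compounds named here, compound 2 stands as the smaller of the two numbers, its only neighbour being compound 1, and since that gap lies within the scatter the two cannot be told apart.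

Compound 3 `CN(c1ccc(Oc2ncnc3ccsc23)cc1)c1nccc(N2CCc3ccccc32)n1` has not yet been measured. It differs from compound 2 as follows: 2,3-dihydro-1H-indol-1-yl in place of piperidin-1-yl on an aromatic carbon. Going by the values given here, the one measured step that bears on this exchange of one ring group for another, a number 4.2 percentage points lower from compound 1 to compound 2 (within the scatter), stayed within the scatter. On that basis the step to compound 3 is expected to be a number 2.3 percentage points higher from compound 2 to compound 3 (within the scatter), with no change beyond the scatter. For compound 3 the estimate in this assay is 68%, between 52% and 82%.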

Compound 3, a percentage reported as inhibition, at one concentration (the size of the read-out at that concentration, not a potency): 58.2%
The estimate for compound 3 lay 9.8 percentage points above the measured number; measured number inside the range.
By their numbers in this assay, from the lowest: compounds 3, 2 and 1 (each within the scatter of the next, the first and the last beyond it).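

In this assay this position now gives its first step beyond the scatter, a number 11.7 percentage points lower from compound 1 to compound 3 (beyond the scatter), a modest change. Set against piperidin-1-yl, the same 2,3-dihydro-1H-indol-1-yl group gives a number 7.5 percentage points lower from compound 2 to compound 3 (within the scatter), so only compound 1 and compound 3 can be told apart, and compound 2 cannot be separated from either; exchanging one ring group for another here can therefore shift the number, but the shift is small. Nothing available explains the gap between compound 1 and compound 3.

Still open, from the compounds shown here alone, is how an open-chain amine such as dimethylamino, or morpholin-4-yl with its second ring hetero atom, would fare on this aromatic carbon. Also open, going by these compounds, is whether the gap seen at this one concentration would reappear in a full potency measurement.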